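The compounds below may be only part of what the source reports. "The series", "measured", "known", "first", "only" and "open" are said of these compounds alone.

Compound 3 `CN1CCC[C@H]1COc1cncc(-c2ccc(F)cc2)c1` gives 0.11 nM in an assay on membranes from brain for binding affinity to Neuronal acetylcholine receptor; alpha4/beta2 (Rattus norvegicus) (a lower number here means a stronger inhibitor, a higher number a weaker inhibitor), the lowest of the three numbers shown, though only the gap to compound 1 is beyond the scatter. Compound 1 `COc1ccc(-c2cncc(OC[C@@H]3CCCN3C)c2)cc1` gives 0.32 nM and compound 2 `CN1CCC[C@H]1COc1cncc(-c2ccc(C(F)(F)F)cc2)c1` gives 0.15 nM. The measured steps are a 2.9-fold lower number from compound 1 to compound 3 (0.46 log units; beyond the scatter), a 2.1-fold lower number from compound 1 to compound 2 (0.33 log units; beyond the scatter) and a 1.4-fold lower number from compound 2 to compound 3 (0.13 log units; within the scatter). Compound 4 `Cc1ccc(-c2cncc(OC[C@@H]3CCCN3C)c2)cc1` differs from compound 3 by methyl in place of fluoro on an aromatic carbon. Going by the values given here, no measured step exchanges fluoro for methyl; the closest evidence is the replacement of methoxy by fluoro or by trifluoromethyl, which moved the number only modestly, and the two halogen-bearing variants sit within the scatter of each other. For compound 4 in this assay a step of a 1.8-fold higher number from compound 3 to compound 4 (0.26 log units; within the scatter) is therefore expected, little beyond the scatter, giving an estimated 0.2 nM with a range of 0.08 nM to 0.5 nM.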

Compound 4, inhibition constant: 0.13 nM
Estimate against measurement, compound 4: 1.5-fold (0.19 log units) above; measured number inside the range.
By their numbers in this assay, from the lowest: compounds 3, 4 and 2 (each within the scatter of the next); then compound 1.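

In this assay, methyl at this place reads the same as the fluoro and trifluoromethyl variants, with a 1.2-fold higher number from compound 3 to compound 4 (0.07 log units; within the scatter) and a 1.2-fold lower number from compound 2 to compound 4 (0.06 log units; within the scatter), so the change from 4-fluorophenyl to 4-methylphenyl leaves the number unmoved within the scatter. Among the four compounds, only the methoxy of compound 1 stands apart, with a 2.5-fold lower number from compound 1 to compound 4 (0.39 log units; beyond the scatter). No measured evidence accounts for these three groups reading alike. On these data alone, whether an amine, a carboxylic acid or a longer chain at this place would hold the number in the same range remains open.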